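The source may report more compounds than this note shows. Statements on the series, on what has been measured and on what is new or still open speak of the compounds shown alone.

In a functional assay on NCI-H460 cells (Homo sapiens) for inhibition, read by MTT assay, with a stated time of 24 h, tested at 10 ug/mL (on this read-out higher numbers stand for more inhibition of growth at the one concentration tested and lower numbers for less inhibition of growth), compound 1 (`O=C(CCCCC1CCSS1)NO`) gives "not active" (no number reported) and no number. In the same read-out compound 2 (`O=C(CCCCC1CCSS1)Nc1ccccc1Cl`) gives 14.6% and compound 3 (`O=C(CCCCC1CCSS1)Nc1ccc(Br)cn1`) gives 38% as the second number of the series. Compound 2 thus holds the lower of the two numbers, and the gap up to compound 3 lies beyond the scatter.

Next to be read is compound 4 (`O=C(CCCCC(S)CCS)Nc1ccccc1Cl`), which differs from compound 2 at one place only. The change is a group of 5 heavy atoms (3 carbon, 2 sulfur; no ring) in place of a group of 5 heavy atoms (3 carbon, 2 sulfur; one five-membered non-aromatic ring with 2 hetero atoms), on a saturated chain carbon, four bonds along the chain from a carbonyl carbon and amounts to a 1,3-disulfanylpropyl group entering in place of the five-membered non-aromatic ring, on a saturated chain carbon, four bonds along the chain from a carbonyl carbon.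

Within the data shown here, all three measured compounds carry that ring, so the series offers no measured precedent for this change, in either direction. The expectation therefore starts from compound 2 at 14.6% as its only anchor, and it stays cautious. The change expected in this assay is a number 3.4 percentage points higher from compound 2 to compound 4 (within the scatter) with no firm direction and no size beyond the scatter. Compound 4 is estimated at 18% (expected range 5% to 40%) on this read-out.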

Compound 4, percent growth inhibition at one concentration: 18.2%
Estimate against measurement, compound 4: 0.2 percentage points below; measured number inside the range.
By their numbers in this assay, from the lowest: compounds 2 and 4 (each within the scatter of the next); then compound 3.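

Among these compounds, replacing the five-membered non-aromatic ring with a 1,3-disulfanylpropyl group, on a saturated chain carbon, four bonds along the chain from a carbonyl carbon, gives the first measured step at this place: a number 3.6 percentage points higher from compound 2 to compound 4 (within the scatter) in this assay. With the rest of compound 2 held constant, the ring form and the open form with its 2 hydrogen-bond donors therefore cannot be told apart on this read-out at the one concentration tested, so keeping the ring closed is not shown to matter here. No measurement is available that bears on why the two forms read alike.

As far as these compounds go, it remains open whether the same replacement would also leave the number unchanged on the amide part of compound 3, which stands beyond the scatter from compound 2, or on the hydroxamic acid end of compound 1, which has no number to compare. Among the compounds shown here, also open is how a carboxylic acid, a single thiol or a longer chain at this place would read in this assay, since the only change seen here keeps the same carbon and sulfur count.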